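Hydrogen for Methyl: Expected Cytotoxicity of Compound 3

The compounds below may be only part of what the source reports. "The series", "measured", "known", "first", "only" and "open" are said of these compounds alone.

Compound 1, `CCC1(Cc2ccccc2)OS(=O)(=O)C=C1OCC#N`: > 400000 nM
Compound 2, `CC(C)C1(Cc2ccccc2)OS(=O)(=O)C=C1OCc1ccccc1`: >= 80000 nM

In an ADME assay on HEL cells (Homo sapiens) for cytotoxicity, with a stated time of 3 days (on this read-out lower numbers stand for higher toxicity in this test and higher numbers for lower toxicity in this test), compound 1 gives > 400000 nM, which is a limit of the assay rather than a number. Compound 2 gives >= 80000 nM in this assay, again only a limit (the limit of >= 80000 nM in this assay, at which 1 of the 2 values shown sits). Compound 2 therefore stands at a limit, and the other value shown is a limit as well (the limit of > 400000 nM in this assay, at which 1 of the 2 values shown sits). Compound 3, `CCC1(Cc2ccccc2)OS(=O)(=O)C=C1OCc1ccccc1`, differs from compound 2 by hydrogen in place of methyl on a saturated chain carbon bound to a saturated chain carbon and a saturated ring carbon. Among the compounds with values here, no step between measured compounds is available, so the expected step that the limit leaves unreadable from compound 2 to compound 3 is none beyond the scatter. Compound 3 is estimated at 200000 nM, within 60000 nM to 500000 nM, most likely reported as a limit.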

Compound 3, minimum cytotoxic concentration: >= 50000 nM
Compound 3: only a limit was reported; the forecaster's own chance of this, stated with the estimate: 85%; the middle value does not contradict the limit.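

Within the data shown here, compound 1, compound 2 and compound 3 all stand only at limits in this assay, so no step among them can be read. The compounds shown leave open whether changing isopropyl to ethyl moves the minimum cytotoxic concentration at all, and by how much.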